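Working notes: from compound 3 to compound 4

The source may report more compounds than this note shows. Statements on the series, on what has been measured and on what is new or still open speak of the compounds shown alone.

Values in a functional assay on MCF7 cells (Homo sapiens) for antiproliferative activity, read by MTT assay, with a stated time of 72 h; on this read-out lower numbers stand for stronger inhibition and higher numbers for weaker inhibition:
- compound 1 `COc1cc(-n2cnc3ccc(-c4ccccc4Cl)cc32)cc(OC)c1OC`: > 10000 nM (a limit of the assay)
- compound 2 `COc1cc(-n2cnc3ccc(-c4ccc(C(C)=O)cc4)cc32)cc(OC)c1OC`: 1540 nM
- compound 3 `COc1cc(-n2cnc3ccc(-c4cccc(C)c4)cc32)cc(OC)c1OC`: 360 nM

Compound 3 has the lowest of the two true numbers, and the value for compound 1 is only a limit. The next compound is compound 4 `COc1ccc(-c2ccc3ncn(-c4cc(OC)c(OC)c(OC)c4)c3c2)cc1`, with 4-methoxyphenyl in place of 3-methylphenyl on an aromatic carbon.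

The nearest guide is a 4.3-fold lower number from compound 2 to compound 3 (0.63 log units; beyond the scatter), which links 3-methylphenyl to 4-acetylphenyl. Read in reverse, it suggests that a 4-substituted phenyl may give a higher number. The other two steps, an at least 6.4-fold lower number from compound 1 to compound 2 (0.81 log units; beyond the scatter) and an at least 27-fold lower number from compound 1 to compound 3 (1.44 log units; beyond the scatter), start from a limit and from 2-chlorophenyl, so they bear little on this change.

In this assay, a small rise is expected, smaller than the gap between compound 3 and compound 2. The expected change is a 1.8-fold higher number from compound 3 to compound 4 (0.26 log units; within the scatter) and may not clear the scatter. For compound 4 the estimate is 650 nM, with an expected range of 150 nM to 2500 nM for this measurement.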

Compound 4, half-maximal inhibitory concentration: 210 nM
Compound 4: the middle estimate sits 3.1-fold (0.49 log units) above what was measured; the range from low to high includes it.
By their numbers in this assay, from the lowest: compounds 4 and 3 (each within the scatter of the next); then compound 2. At a limit, above all of these: compound 1.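

In this assay, 4-methoxyphenyl and 3-methylphenyl on this aromatic carbon cannot be told apart: a 1.7-fold lower number from compound 3 to compound 4 (0.23 log units; within the scatter). With a 4-substituted phenyl kept in place, methoxy in place of acetyl gives a 7.3-fold lower number from compound 2 to compound 4 (0.87 log units; beyond the scatter), so the higher number of compound 2 goes with the acetyl group and not with a 4-substituted phenyl as such. Compound 1 stands at a limit of the assay, > 10000 nM, and this leaves only a bound on the change to 4-methoxyphenyl: an at least 47-fold lower number from compound 1 to compound 4 (1.67 log units; beyond the scatter).

Compound 3 and compound 4 differ in both the group and its place on the phenyl, so the two contributions remain unseparated. Going by these compounds, how an amine or a hydroxyl group on this phenyl would read in this assay also remains open.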